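Working notes: from compound 2 to compound 3

The compounds below may be only part of what the source reports. "The series", "measured", "known", "first", "only" and "open" are said of these compounds alone.

Measured in a functional assay on NCI-H520 cells (Homo sapiens); on this read-out lower numbers stand for stronger inhibition of growth and higher numbers for weaker inhibition of growth:
- compound 1 `O=S(=O)(/C=C/c1ccc(Br)cc1)Cc1ccc(Nc2ncnc3ccccc23)cc1`: > 100000 nM (a limit)
- compound 2 `O=S(=O)(/C=C/c1ccc(Cl)c(Cl)c1)Cc1ccc(Nc2ncnc3ccc(Br)cc23)cc1`: > 100000 nM (a limit)

Compound 2 stands at > 100000 nM, which is a limit and not a number. Among the compounds with values here, it has no measured value to rank against compound 1, since the series so far offers only (the limit of > 100000 nM in this assay, at which 2 of the 2 values shown sit).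

Compound 3 `O=S(=O)(/C=C/c1ccc(Br)cc1)Cc1ccc(Nc2ncnc3ccc(Br)cc23)cc1` has not yet been measured. It differs from compound 2 by a single change: 4-bromophenyl in place of 3,4-dichlorophenyl on a double-bonded chain carbon bound to a double-bonded chain carbon. In words, 4-bromophenyl replaces 3,4-dichlorophenyl on a double-bonded chain carbon bound to a double-bonded chain carbon.

Within the data shown here, no measured pair differs in one place, so the size of this change cannot be read from the series. In this assay, no step beyond the scatter is expected, and the most likely report is again only a limit. This expectation rests on compound 2 at > 100000 nM, a limit.

The estimated step runs a number no higher from compound 2 to compound 3 (the limit leaves the size open). Compound 3 is estimated at 100000 nM, with an expected range of 40000 nM to 200000 nM.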

Compound 3, concentration for 50% growth inhibition: 20000 nM
The estimate for compound 3 lay 5.0-fold (0.70 log units) above the measured number; the measured number lies below the stated range.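

In this assay, within the data shown here, compound 3 is the first compound to give a number rather than a limit, so both places on the molecule now register a change. At the first place, 4-bromophenyl in place of 3,4-dichlorophenyl on a double-bonded chain carbon bound to a double-bonded chain carbon gives an at least 5.0-fold lower number from compound 2 to compound 3 (0.69 log units; beyond the scatter), and at the second, bromo in place of hydrogen on an aromatic carbon gives an at least 5.0-fold lower number from compound 1 to compound 3 (0.69 log units; beyond the scatter). Each step is a lower bound and not a size, because its starting compound stands at a limit: the limit of > 100000 nM in this assay, at which 2 of the 3 values shown sit.

The compounds shown leave open whether the step from the 3,4-dichlorophenyl group depends on the bromine itself or on having a single halogen on that ring, a question that 4-chlorophenyl on the same chain carbon would address. They also leave open how the number in this assay responds to a group of another kind, such as an amine or a carboxylic acid on that ring, or to a longer chain in place of the ethenyl link.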